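The source may hold more compounds than are shown below. What is called first, only, known or untested is meant among the compounds shown, and "the series" means these compounds.

Values in a functional assay on HeLa cells (Homo sapiens) for inhibition; a higher number here means a weaker inhibitor, a lower number a stronger inhibitor:
Compound 1 `CCN(CC)CCNC(=O)CC(CC(=O)NC1Cc2ccccc2C1)c1ccc(Cl)cc1`: 50500 nM
Compound 2 `O=C(CC(CC(=O)NC1Cc2ccccc2C1)c1ccccc1)NCCN1CCCC1`: > 100000 nM, a limit
Compound 3 `CCN(CC)CCNC(=O)CC(CC(=O)NC1Cc2ccccc2C1)c1ccccc1`: > 100000 nM, a limit

Within the data shown here, compound 1 gives the only actual number. Compound 3 has no number, and its > 100000 nM is a limit. It shares that position with compound 2, as the limit of > 100000 nM in this assay, at which 2 of the 3 values shown sit, records.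

Compound 4 `CCN(CC)CCNC(=O)CC(CC(=O)N(C)C1Cc2ccccc2C1)c1ccccc1` follows from compound 3 by one change: methyl in place of hydrogen on an amide-type nitrogen. Two measured steps exist nearby. Hydrogen in place of chloro gives an at least 1.9-fold higher number from compound 1 to compound 3 (0.29 log units; that floor lies within the scatter). Diethylamino in place of pyrrolidin-1-yl gives a step that the two limits leave unreadable from compound 2 to compound 3. Neither step alters the amide-type nitrogen that now carries the methyl, so neither gives a size or direction for this change. No step beyond the scatter is therefore expected in this assay, and a further limit is the likeliest report. The expected change is a number no higher from compound 3 to compound 4 (the limit leaves the size open). For compound 4 the estimate is 100000 nM, with an expected range from 40000 nM to 250000 nM.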

Compound 4, half-maximal inhibitory concentration: > 100000 nM
Compound 4: a limit, no number; the forecaster's own chance of this, stated with the estimate: 75%; the middle value sits exactly at the limit.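

In this assay compound 4 gives > 100000 nM, a limit and not a number. Compound 3 also sits at a limit, so the step from compound 3 to compound 4 cannot be read. The compounds shown leave open whether methyl in place of hydrogen on this amide-type nitrogen changes inhibition at all.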